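The source may hold more compounds than are shown below. What is called first, only, known or untested is meant among the compounds shown, and "the series" means these compounds.

Measured compounds:
- compound 1, `COc1cc(OC)c(OC)cc1/C=C/COC(=O)/C=C/c1ccc(Br)cc1`, giving 100%
- compound 2, `COc1cc(OC)c(OC)cc1/C=C/COC(=O)/C=C/c1cc(OC)c(OC)c(OC)c1`, giving 100%

Both values come from a functional assay on the whole organism (strain Kunming) with Mus musculus as the target, with a stated time of 0.5 h, at a dose of 100 mg/kg by the intraperitoneal route; a lower number here means a stronger effect, a higher number a weaker effect of the compound at the dose given. On these numbers compound 1 stands level with compound 2 at the digits shown; the two are within the usual scatter of each other, so no ordering between them can be read off. Each shares the same core, and they differ only in the ring at the far end of the chain, which here makes no difference that the numbers can resolve.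

Compound 3, `COc1cccc(/C=C/C(=O)OC/C=C/c2cc(OC)c(OC)cc2OC)c1`, has not yet been measured in this assay. It differs from compound 1 in one place: 3-methoxyphenyl in place of 4-bromophenyl on a double-bonded chain carbon bound to a double-bonded chain carbon. Among the measured compounds shown here, no step between two measured compounds has been recorded, so the size of this change has to be guessed. Because compound 1 gives 100% and compound 2 gives 100% with a different ring in the same place, a step within the scatter is expected, with a slight lean toward a lower number rather than a higher one. The expected step is a number 5 percentage points lower from compound 1 to compound 3 (within the scatter). For compound 3 the estimated value is 95%, expected between 70% and 100%.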

Compound 3, a percentage reported as activity, at one dose (the size of the read-out at that dose, not a potency): 100%
For compound 3 the middle estimate is 5 percentage points below the measured one, and the stated range covers the measured number.
By their numbers in this assay, from the lowest: compounds 1, 2 and 3 (each within the scatter of the next).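

In this assay, among the compounds shown here, putting 3-methoxyphenyl in place of 4-bromophenyl on a double-bonded chain carbon bound to a double-bonded chain carbon gives no change at the digits printed from compound 1 to compound 3 (within the scatter) and is the first step at this position that can be read directly. Swapping a bromine-bearing ring for an oxygen-bearing one therefore leaves the read-out unmoved at this dose, and compound 3 joins the earlier pair at the same printed level: compound 1 gives 100% and compound 2 gives 100% in the same assay. Nothing at hand accounts for this sameness.

For the compounds shown here, the three compounds show only that these substituted phenyl rings cannot be told apart here, so they do not reveal whether this position can influence the read-out at all. A phenyl ring carrying an amine or a carboxylic acid, or a longer chain in place of the ring, could still give a number that differs from the one shared so far.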